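Amine Ring Size and Cytotoxicity in Rat L6 Cells

This account rests on a few compounds, and the source may have more. Where it says the series, first, only, none or still open, it means among the compounds named here.

Compound 1 `OC1CC2(N3CCCC3)CC(c3ccccc3)C1C(c1ccccc1)C2` and compound 2 `OC1CC2(N3CCCCC3)CC(c3ccccc3)C1C(c1ccccc1)C2` share a core and differ in one place. In an ADME assay on L6 cells (Rattus norvegicus) for cytotoxicity (on this read-out higher numbers stand for weaker inhibition and lower numbers for stronger inhibition), compound 1 gives 26800 nM, and compound 2 gives 37300 nM. The change piperidin-1-yl in place of pyrrolidin-1-yl on a saturated ring carbon made a 1.4-fold higher number from compound 1 to compound 2 (0.14 log units; within the scatter). Compound 3 `COc1ccc(C2CC3(N4CCCC4)CC(O)C2C(c2ccc(OC)cc2)C3)cc1` rests on a different core; the difference between the two cores is not broken down here. In this assay compound 3 gives 17900 nM. Compound 4 `COc1ccc(C2CC3(N4CCCCC4)CC(O)C2C(c2ccc(OC)cc2)C3)cc1` is compound 3 carrying the same kind of change, (piperidin-1-yl in place of pyrrolidin-1-yl on a saturated ring carbon); around the place, the ring atom bearing a 4-methoxyphenyl group stands where compound 1 has a ring atom bearing a phenyl group. Because the earlier step of a 1.4-fold higher number from compound 1 to compound 2 (0.14 log units; within the scatter) stayed within the scatter, compound 4 is expected to give 24000 nM in this assay, between 12000 nM and 48000 nM, an estimated step of a 1.3-fold higher number from compound 3 to compound 4 (0.13 log units; within the scatter).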

Compound 4, half-maximal inhibitory concentration: 44600 nM
Estimate against measurement, compound 4: 1.9-fold (0.27 log units) below; the measured number falls inside the stated range.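

On the core with the 4-methoxyphenyl groups, piperidin-1-yl in place of pyrrolidin-1-yl made a 2.5-fold higher number from compound 3 to compound 4 (0.40 log units; beyond the scatter) in this assay. Set beside the earlier step, the two cannot be told apart in size: the same change on two cores in this assay, a 1.4-fold higher number (0.14 log units; within the scatter) from compound 1 to compound 2 and a 2.5-fold higher number (0.40 log units; beyond the scatter) from compound 3 to compound 4, 1.8-fold (0.25 log units) apart, within the scatter of two such steps. The change thus carried over between these two cores without a measurable difference, but only the second step lies beyond the scatter, and two pairs show nothing about any further core.

The compounds shown leave open how other amines on the same saturated ring carbon, such as morpholin-4-yl or an open-chain dimethylamino group, would read in this assay. Also open, as far as these compounds go, is whether a ketone carbonyl in place of the hydroxy group would shift these numbers.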